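The source may report more compounds than this note shows. Statements on the series, on what has been measured and on what is new or still open speak of the compounds shown alone.

Compound 1 `Nc1cc(N)c2nc(-c3ccccc3)c(Oc3ccc(F)cc3)nc2c1` gives the highest number of the three measured compounds in a functional assay on RPMI8266 cells (Homo sapiens) for inhibition, read by sulforhodamine B assay, with a stated time of 48 h (a lower number here means a stronger inhibitor of growth, a higher number a weaker inhibitor of growth), at 12300 nM. Compound 2 `COc1cc(CNc2nc3cc(N)cc(N)c3nc2-c2ccccc2)cc(OC)c1OC` gives 692 nM, and compound 3 `COc1ccc(CNc2nc3cc(N)cc(N)c3nc2-c2ccccc2)cc1OC` gives 2140 nM. Going by the values given here, the only measured step, a 3.1-fold higher number from compound 2 to compound 3 (0.49 log units; beyond the scatter), concerns a different part of the molecule from the one changed here. Compound 4 `COc1ccc(Sc2nc3cc(N)cc(N)c3nc2-c2ccccc2)cc1` differs from compound 1 by (4-methoxyphenyl)sulfanyl in place of 4-fluorophenoxy on an aromatic carbon. Among the compounds with values here, no measured step bears directly on this exchange; compounds 2 and 3 show only that other groups at this place give lower numbers than compound 1. A downward step of moderate size, a 2.5-fold lower number from compound 1 to compound 4 (0.39 log units; beyond the scatter), is therefore expected, with wide uncertainty. Compound 4 is estimated at 5000 nM, within a range from 1500 nM to 17000 nM.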

Compound 4, concentration for 50% growth inhibition: 3980 nM
Estimate against measurement, compound 4: 1.3-fold (0.10 log units) above, within the range that was stated.
By their numbers in this assay, from the lowest: compound 2; then compounds 3 and 4 (each within the scatter of the next); then compound 1.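

In this assay, going by these compounds alone, placing (4-methoxyphenyl)sulfanyl where 4-fluorophenoxy stood on this aromatic carbon gives a 3.1-fold lower number from compound 1 to compound 4 (0.49 log units; beyond the scatter) and provides the first direct reading of an exchange at this place. The step is beyond the scatter, but the linking atom and the group on the outer ring change together, so their separate contributions cannot be read. No measurement shown accounts for the step. As far as these compounds go, how 4-methoxyphenoxy or 4-fluorophenylsulfanyl would read at this place remains open, and these would separate the two changes. From the compounds shown here alone, the effect of a carboxylic acid on that outer ring also remains open.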